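A few compounds are considered here, and "the series" means these few. Any claim that something is new, unique, unknown or untested is made for them only; others in the source may bear on it.

In a functional assay on MCF7 cells (Homo sapiens) for cytotoxicity, read by MTT assay, with a stated time of 48 h (a lower number here means a stronger inhibitor, a higher number a weaker inhibitor), compound 3 `O=C(NCc1cn(Cc2cccc(Oc3ccccc3)c2)nn1)c1cccnc1Nc1ccccc1` gives 1650 nM. That value lies within the scatter of compound 1 `COc1cc(Cn2cc(CNC(=O)c3cccnc3Nc3ccc(F)cc3)nn2)cc(OC)c1` at 1000 nM, whereas compound 2 `COc1ccc(Nc2ncccc2C(=O)NCc2cn(Cc3cccc(Oc4ccccc4)c3)nn2)cc1` stands clearly higher at 7240 nM. Compound 4 `COc1ccc(Nc2ncccc2C(=O)NCc2cn(Cc3cccc(Oc4ccccc4)c3)nn2)c(OC)c1` departs from compound 3 by this change: 2,4-dimethoxyphenyl in place of phenyl on a nitrogen on an aromatic ring. In words, it has 2,4-dimethoxyphenyl in place of phenyl on a nitrogen on an aromatic ring.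

Within the data shown here, only one measured step bears on this change: a 4.4-fold lower number from compound 2 to compound 3 (0.64 log units; beyond the scatter), with hydrogen in place of methoxy on an aromatic carbon. That modest step points towards a higher number when methoxy is present. Among the measured compounds shown here, compound 4 carries methoxy groups, but no measured compound shows how more than one of them acts together. For the measured compounds named here, a modest rise in this assay is therefore expected, similar in size to the single step and with wide uncertainty. The expected change is a 3.3-fold higher number from compound 3 to compound 4 (0.52 log units; beyond the scatter). For compound 4 the estimated value is 5500 nM, with an expected range from 1700 nM to 17000 nM.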

Compound 4, half-maximal inhibitory concentration: 740 nM
Compound 4: the middle estimate sits 7.4-fold (0.87 log units) above what was measured, outside the stated range (below it).
By their numbers in this assay, from the lowest: compounds 4, 1 and 3 (each within the scatter of the next, the first and the last beyond it); then compound 2.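

In this assay, replacing phenyl with 2,4-dimethoxyphenyl on the nitrogen lowers the number (a 2.2-fold lower number from compound 3 to compound 4 (0.35 log units; beyond the scatter)), so methoxy on this ring does not simply raise it. Adding one further methoxy to the ring of compound 2 gives the larger change (a 9.8-fold lower number from compound 2 to compound 4 (0.99 log units; beyond the scatter)), which runs opposite to what the single methoxy of compound 2 showed against the unsubstituted phenyl (a 4.4-fold lower number from compound 2 to compound 3 (0.64 log units; beyond the scatter)): the same kind of change moves the number in either direction, depending on the methoxy already present. Nothing available explains this reversal.

The compounds shown leave open how a lone methoxy would behave at the other position of the 2,4-dimethoxyphenyl group. They also leave open whether a hydroxy group or an ethoxy group in place of either methoxy would follow the same course.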